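Methoxy for Methyl on a Fused Aromatic Core

This account rests on a few compounds, and the source may have more. Where it says the series, first, only, none or still open, it means among the compounds named here.

Going by the values given here, compound 2 `Cc1cc2c(c3c1C[C@@H]1[C@@H](C)CO[C@]1(C)O3)C[C@@H]1[C@@H](C)CO[C@]1(C)O2` is one of two compounds measured in a functional assay on aorta (Rattus norvegicus, strain Sprague-Dawley) for inhibition (on this read-out lower numbers stand for an effect already at smaller amounts and higher numbers for an effect only at larger amounts of compound), where compound 2 gives 52000 nM. This is the higher of the two numbers, yet compound 1 `C[C@H]1CO[C@]2(C)Oc3c(c4c(c5c3C[C@@H]3[C@@H](C)CO[C@]3(C)O5)C[C@@H]3[C@@H](C)CO[C@]3(C)O4)C[C@H]12` gives 31000 nM, a value within the usual scatter of that of compound 2, so the two cannot be told apart. Compound 3 `COc1cc2c(c3c1C[C@@H]1[C@@H](C)CO[C@]1(C)O3)C[C@@H]1[C@@H](C)CO[C@]1(C)O2` has not been measured. It differs from compound 2 by a single change: methoxy in place of methyl on an aromatic carbon. Among the compounds with values here, no measured pair shows what this change does here. The step of a 1.2-fold lower number from compound 2 to compound 3 (0.06 log units; within the scatter) is therefore expected to stay within the scatter. For compound 3 the estimate is 45000 nM, with a range from 15000 nM to 130000 nM.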

Compound 3, half-maximal effective concentration: 33000 nM
Compound 3: middle estimate off by 1.4-fold (0.13 log units), on the high side, within the range that was stated.
By their numbers in this assay, from the lowest: compounds 1, 3 and 2 (each within the scatter of the next).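

In this assay, going by these compounds alone, placing methoxy instead of methyl on this aromatic carbon gives a 1.6-fold lower number from compound 2 to compound 3 (0.20 log units; within the scatter) and so provides the first direct reading of this change. At this position, the swap from methyl to methoxy brings in an oxygen and a hydrogen-bond acceptor, yet the two compounds cannot be told apart. No measurement shown here explains this result. From the compounds shown here alone, it remains open whether an amine or a carboxylic acid on this carbon would give a number beyond the scatter. The same question applies to a longer chain, such as ethoxy.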